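Arylpiperazine replacements for the amide on the shared core

A few compounds are considered here, and "the series" means these few. Any claim that something is new, unique, unknown or untested is made for them only; others in the source may bear on it.

Compound 1 `NCCNc1cc(N2CCN(C(=O)CCc3ccccc3)CC2)nc2ccccc12` is the reference point. In an ADME assay on HEp-2 cells (Homo sapiens) for cytotoxicity, read by CCK-8 assay, with a stated time of 6 days (on this read-out lower numbers stand for higher toxicity in this test and higher numbers for lower toxicity in this test), compound 1 gives > 100000 nM, which is a limit of the measurement (the limit of > 100000 nM in this assay, at which 1 of the 2 values shown sits). Compound 2 `NCCNc1cc(N2CCN(c3ccccc3Cl)CC2)nc2ccccc12` carries 2-chlorophenyl in place of phenethylcarbonyl on an amine nitrogen in a ring; in this assay compound 2 gives 20800 nM. The resulting step of an at least 4.8-fold lower number from compound 1 to compound 2 (0.68 log units; beyond the scatter) is the only measured move of this kind in the set. Compound 3 `NCCNc1cc(N2CCN(c3ccc(Cl)cc3)CC2)nc2ccccc12` is not yet measured and differs from compound 1 as follows: 4-chlorophenyl in place of phenethylcarbonyl on an amine nitrogen in a ring. This is the same kind of exchange as the one behind an at least 4.8-fold lower number from compound 1 to compound 2 (0.68 log units; beyond the scatter), the entering group again being a chlorophenyl, so a step of comparable size in the same direction is expected in this assay. Compound 3 is therefore estimated at 25000 nM, with a range from 8000 nM to 100000 nM. Among the measured compounds shown here, the expected step of an at least 4.0-fold lower number from compound 1 to compound 3 (0.60 log units; beyond the scatter) rests on the single measured analogue, compound 2.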

Compound 3, half-maximal cytotoxic concentration: 6600 nM
For compound 3 the middle estimate is 3.8-fold (0.58 log units) above the measured one; the whole stated range lies above it.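

In this assay the two chlorophenyl groups do not read alike on the amine nitrogen in a ring: 4-chlorophenyl in place of 2-chlorophenyl gives a 3.2-fold lower number from compound 2 to compound 3 (0.50 log units; beyond the scatter), so the outcome at this position depends on more than the entry of a chlorophenyl group. Replacing phenethylcarbonyl with 4-chlorophenyl gives an at least 15-fold lower number from compound 1 to compound 3 (1.18 log units; beyond the scatter), the larger of the two moves away from the amide shown so far. The value for compound 1 is a limit and not a number: the limit of > 100000 nM in this assay, at which 1 of the 3 values shown sits.

Still open, from the compounds shown here alone, is how an unsubstituted phenyl, a 4-fluorophenyl or a 4-methoxyphenyl would fall on this nitrogen relative to the two chlorophenyl compounds. Also open, going by these compounds, is whether a benzyl group or a shorter acyl group such as acetyl would stay nearer to compound 1 or to compound 3.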